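Selenocyanate and Diselenide Carbamates: Cytotoxicity Notes

The source may report more compounds than this note shows. Statements on the series, on what has been measured and on what is new or still open speak of the compounds shown alone.

Measured compounds:
- compound 1, `CC(C)COC(=O)Nc1ccc([Se]C#N)cc1`: 63700 nM
- compound 2, `N#C[Se]c1ccc(NC(=O)Oc2ccc(F)cc2)cc1`: 66500 nM
- compound 3, `O=C(Nc1ccc([Se][Se]c2ccc(NC(=O)Oc3ccc(F)cc3)cc2)cc1)Oc1ccc(F)cc1`: 85300 nM

In a functional assay on HT-29 cells (Homo sapiens) for cytotoxicity, read by MTT assay, with a stated time of 72 h (a higher number here means that more compound is tolerated, a lower number that less compound is tolerated), compound 1 gives 63700 nM. Compound 2 gives 66500 nM and compound 3 gives 85300 nM. Compound 1 sits at the low end of the three numbers, but its gaps to compound 2 and to compound 3 both fall within the scatter of this assay, so the three compounds cannot be told apart on these data.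

The unmeasured compound 4, `N#C[Se]c1ccc(NC(=O)OCc2ccccc2)cc1`, differs from compound 1 in one place: phenyl in place of isopropyl on a saturated chain carbon bound to an oxygen next to a carbonyl group. Among the measured compounds shown here, no measured pair isolates a change of this kind, so there is no step to lean on. Since the carbamate variation between compound 1 and compound 2 leaves the numbers within the scatter, the expectation for compound 4 is a step of a 1.1-fold lower number from compound 1 to compound 4 (0.03 log units; within the scatter) that stays within the scatter, with no particular direction. Compound 4 is therefore estimated at 60000 nM in this assay, with a range from 30000 nM to 120000 nM.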

Compound 4, concentration lethal to 50% of the cells: 69100 nM
The estimate for compound 4 lay 1.2-fold (0.06 log units) below the measured number, within the range that was stated.
By their numbers in this assay, from the lowest: compounds 1, 2, 4 and 3 (each within the scatter of the next).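

Phenyl in place of isopropyl on a saturated chain carbon bound to an oxygen next to a carbonyl group gives, in this assay, a 1.1-fold higher number from compound 1 to compound 4 (0.04 log units; within the scatter), and this is the first change in the series that can be read at a single place. At this position, one six-membered aromatic ring of carbon only can thus replace a ringless group of 3 heavy atoms without a step beyond the scatter. No measurement on hand gives a reason for this flat result.

This reading rests on a single pair, so it cannot be extended to other groups at this position. From the compounds shown here alone, whether an amine, a carboxylic acid or a longer chain on this carbon would give a step beyond the scatter stays open.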